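Cyclohexyl replaced by 4-methylbenzyl in the amide series

The compounds below may be only part of what the source reports. "The series", "measured", "known", "first", "only" and "open" are said of these compounds alone.

Measured so far:
compound 1, `CC1CCN(c2nc(C(F)(F)F)ccc2CNC(=O)C(c2ccc(NS(C)(=O)=O)c(F)c2)C2CCCCC2)CC1`, 31.1 nM
compound 2, `CS(=O)(=O)Nc1ccc(C(C(=O)NCc2ccc(C(F)(F)F)nc2SC2CCCCC2)C2CCCCC2)cc1F`, "active" (no number reported)

In an assay on CHO cells for antagonist activity at transient receptor potential cation channel subfamily V member 1 (Homo sapiens), read by FLIPR (on this read-out lower numbers stand for stronger inhibition and higher numbers for weaker inhibition), compound 1 gives 31.1 nM. Compound 2 is recorded in this assay as "active" (no number reported), so no number fixes where it stands; it is only known to inhibit, and its place relative to compound 1 cannot be read from the data.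

Compound 3, `Cc1ccc(CC(C(=O)NCc2ccc(C(F)(F)F)nc2SC2CCCCC2)c2ccc(NS(C)(=O)=O)c(F)c2)cc1`, carries the change (4-methylbenzyl in place of cyclohexyl on a saturated chain carbon bound to an aromatic carbon and a carbonyl carbon). Within the data shown here, no measured pair shows this exchange, so the size of the step from compound 2 to compound 3 in this assay is unknown; with compound 2 lacking a number, a step beyond the scatter in either direction is as plausible as none. Taking compound 1 as the only numbered anchor for the series, compound 3 is expected near 60 nM, with a range of 10 nM to 400 nM.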

Compound 3, inhibition constant: 40.3 nM
For compound 3 the middle estimate is 1.5-fold (0.17 log units) above the measured one; the range from low to high includes it.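

Among these compounds, compound 2 carries no number, only the entry "active", so no step to compound 3 can be read. The compounds shown leave open how far, and in which direction, 4-methylbenzyl in place of cyclohexyl moves inhibition. No evidence on this result is available.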